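This account rests on a few compounds, and the source may have more. Where it says the series, first, only, none or still open, it means among the compounds named here.

Working notes on the series. Compound 1 `Cc1cc(/C=C2\SC(=S)N(Cc3ccccc3)C2=O)c(C)n1-c1ccc(O)c(C(=O)O)c1` gives 159000 nM in an ADME assay on MT2 cells (Homo sapiens) for cytotoxicity, read by XTT assay, with a stated time of 4 days; on this read-out higher numbers stand for lower toxicity in this test and lower numbers for higher toxicity in this test. Compound 2 `Cc1cc(/C=C2\SC(=S)N(Cc3ccc(C(F)(F)F)cc3)C2=O)c(C)n1-c1ccc(O)c(C(=O)O)c1` gives 45900 nM in this assay, and compound 3 `Cc1cc(/C=C2\SC(=S)N(Cc3ccc(Br)cc3)C2=O)c(C)n1-c1ccc(O)c(C(=O)O)c1` gives 94400 nM in this assay. Among these three, compound 2 stands at the lowest number: the step of a 3.5-fold lower number from compound 1 to compound 2 (0.54 log units; beyond the scatter) and the step of a 2.1-fold higher number from compound 2 to compound 3 (0.31 log units; beyond the scatter) both set it apart, while a 1.7-fold lower number from compound 1 to compound 3 (0.23 log units; within the scatter) leaves compound 1 and compound 3 close to each other.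

The next compound, compound 4 `Cc1cc(/C=C2\SC(=S)N(Cc3ccc(C(=O)O)cc3)C2=O)c(C)n1-c1ccc(O)c(C(=O)O)c1`, differs from compound 2 by carboxy in place of trifluoromethyl on an aromatic carbon. Within the data shown here, no measured step carries a carboxy group at this place, so the expectation rests on the two steps that remove the trifluoromethyl from compound 2 or add it: a 2.1-fold higher number from compound 2 to compound 3 (0.31 log units; beyond the scatter) shows the number rising once the trifluoromethyl is gone, and a 3.5-fold lower number from compound 1 to compound 2 (0.54 log units; beyond the scatter) shows it falling when the trifluoromethyl arrives. Both point the same way, so a higher number is expected for compound 4 in this assay, of about the size seen in those steps or somewhat larger, estimated as a 3.3-fold higher number from compound 2 to compound 4 (0.51 log units; beyond the scatter). Compound 4 is expected to give 150000 nM in this assay, with a range from 60000 nM to 400000 nM.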

Compound 4, half-maximal cytotoxic concentration: 105000 nM
Estimate against measurement, compound 4: 1.4-fold (0.15 log units) above; measured number inside the range.
By their numbers in this assay, from the lowest: compound 2; then compounds 3, 4 and 1 (each within the scatter of the next).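

In this assay, trifluoromethyl now stands apart from a second replacement at this place, and one of a different kind: the 4-(trifluoromethyl)benzyl to 4-carboxybenzyl change gives a 2.3-fold higher number from compound 2 to compound 4 (0.36 log units; beyond the scatter), so the separation of compound 2 does not rest on bromo and hydrogen alone. Carboxy, by contrast, does not separate from the other two groups, since a 1.1-fold higher number from compound 3 to compound 4 (0.05 log units; within the scatter) and a 1.5-fold lower number from compound 1 to compound 4 (0.18 log units; within the scatter) both lie within the scatter. Among the four compounds, hydrogen, bromo and carboxy therefore form one group in this assay, with compound 2 alone beyond the scatter of each of the others and no compound going against this pattern. The available data offer nothing that bears on why trifluoromethyl alone stands apart at this place.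

On these data alone, it remains open whether an amine, a nitrile or a methoxy group on this aromatic carbon would fall with trifluoromethyl or with the other three groups. Also open, as far as these compounds go, is whether a longer chain carrying the carboxylic acid, in place of the 4-carboxybenzyl group, would keep the number of compound 4.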